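A few compounds are considered here, and "the series" means these few. Any claim that something is new, unique, unknown or untested is made for them only; others in the source may bear on it.

Measured compounds:
- compound 1, `CCCCN(CCCC)C(=O)Nc1ccc(Cl)c(C(F)(F)F)c1`: 3.69 ug/mL
- compound 2, `CCOc1ccc(NC(=O)N(Cc2ccccc2)Cc2ccccc2)cc1`: 3.47 ug/mL
- compound 3, `O=C(Nc1cccc(Cl)c1)N(Cc1ccccc1)Cc1ccccc1`: 2.72 ug/mL

All three were tested in an assay on isolated protein for inhibition of sterol O-acyltransferase 1 (Rattus norvegicus); a higher number here means a weaker inhibitor, a lower number a stronger inhibitor. Compound 3 has the lowest of the three numbers, but its gaps to compound 2 and to compound 1 both lie within the scatter, so the three cannot be told apart on these data.

Compound 4, `O=C(Nc1cccc(Br)c1)N(Cc1ccccc1)Cc1ccccc1`, has not yet been measured. It differs from compound 3 in one place: bromo in place of chloro on an aromatic carbon. Going by the values given here, the only measured step on this ring is the swap of the whole group, a 1.3-fold lower number from compound 2 to compound 3 (0.11 log units; within the scatter), which stayed within the scatter. Among the compounds with values here, no measured pair compares one halogen with another, so there is nothing in these numbers pointing toward a larger step for a change as small as chloro to bromo.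

The step from compound 3 to compound 4 in this assay is therefore expected to be a 1.1-fold higher number from compound 3 to compound 4 (0.03 log units; within the scatter), that is, no change beyond the scatter. Compound 4 is estimated at 2.9 ug/mL, in a range from 1.5 ug/mL to 5.5 ug/mL.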

Compound 4, half-maximal inhibitory concentration: 2.28 ug/mL
Compound 4: the middle estimate sits 1.3-fold (0.10 log units) above what was measured; measured number inside the range.
By their numbers in this assay, from the lowest: compounds 4, 3, 2 and 1 (each within the scatter of the next).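

In this assay, bromo in place of chloro gives a 1.2-fold lower number from compound 3 to compound 4 (0.08 log units; within the scatter), so on this aromatic carbon, meta to a large group, these two halogens cannot be told apart. Replacing the whole 4-ethoxyphenyl group with 3-bromophenyl gives a 1.5-fold lower number from compound 2 to compound 4 (0.18 log units; within the scatter), so even this larger swap on the amide-type nitrogen does not separate the two compounds. Nothing available here speaks to what lies behind these results.

Still open, on these data alone, is whether any group at this position can move the number beyond the scatter, for example an amine, a carboxylic acid or a nitrile in place of the halogen. Also open, as far as these compounds go, is what a change to the two benzyl groups alone would do, as compound 1 differs from compound 4 in more than one place.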